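The compounds below may be only part of what the source reports. "The series", "measured", "known", "first", "only" and "open" are said of these compounds alone.

Compound 2 `CC(=O)OCc1ccc2oc(=O)c(C(=O)Sc3cccc(Cl)c3)cc2c1` was tested in a functional assay on HT-1080 cells (Homo sapiens), read by transwell migration, with a stated time of 24 h, tested at 1 uM (a lower number here means a stronger effect, a higher number a weaker effect of the compound at the concentration tested), and gave 65.8%. Among the compounds with values here, of the two compounds measured so far it stands highest: compound 1 `CC(=O)OCc1ccc2oc(=O)c(C(=O)Oc3cccc(Br)c3)cc2c1` gave 21.8%, and the step of a number 44 percentage points higher from compound 1 to compound 2 (beyond the scatter) is a large one. Within the data shown here, that step replaced a 3-bromophenoxy group with a (3-chlorophenyl)sulfanyl group on a carbonyl carbon, so two things changed at once, and it is the only measured step available here.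

Compound 3 `CC(=O)OCc1ccc2oc(=O)c(C(=O)Nc3cccc(Cl)c3)cc2c1` has not yet been measured in this assay. Its change from compound 2 is (3-chlorophenyl)amino in place of (3-chlorophenyl)sulfanyl on a carbonyl carbon. Among the measured compounds shown here, no measured step swaps a (3-chlorophenyl)sulfanyl group for a (3-chlorophenyl)amino group, so the direction of this change is not settled by the data; the step of a number 44 percentage points higher from compound 1 to compound 2 (beyond the scatter) only shows that exchanging the group attached to this carbonyl carbon can move the read-out far. For compound 3 the estimated step of a number 20.8 percentage points lower from compound 2 to compound 3 (beyond the scatter) is therefore taken as a move back toward a lower number, with wide uncertainty. Compound 3 is expected to give about 45%, between 20% and 80%.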

Compound 3, a percentage reported as activity, at one concentration (the size of the read-out at that concentration, not a potency): 66.9%
For compound 3 the middle estimate is 21.9 percentage points below the measured one; the measured number falls inside the stated range.
By their numbers in this assay, from the lowest: compound 1; then compounds 2 and 3 (each within the scatter of the next).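

In this assay the exchange of (3-chlorophenyl)sulfanyl for (3-chlorophenyl)amino on the carbonyl carbon gives a number 1.1 percentage points higher from compound 2 to compound 3 (within the scatter) and so the two groups cannot be told apart in this read-out, even though only the amino group carries a hydrogen-bond donor. The step of a number 45.1 percentage points higher from compound 1 to compound 3 (beyond the scatter) is large as well, which shows that the distance from compound 1 is not tied to the sulfur link alone: it appears with the nitrogen link too. The data available here give no reason for these numbers.

Compound 1 differs from compound 2 and from compound 3 both in the atom that joins the aromatic ring to the carbonyl carbon and in the halogen on that ring, so the compounds shown leave open which of these two differences goes with the large steps. A 3-chlorophenoxy group on the same carbonyl carbon, which keeps the oxygen link of compound 1 and the chlorine of compound 2 and compound 3, would separate the two.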